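Swapping Fluoro for Methoxy on a Shared Core

A few compounds are considered here, and "the series" means these few. Any claim that something is new, unique, unknown or untested is made for them only; others in the source may bear on it.

Compound 1 `COc1ccc(-c2ccnc(Nc3ccc([N+](=O)[O-])cc3)n2)cc1`: 2730 nM
Compound 2 `COc1cccc(Nc2nccc(-c3ccc(F)cc3)n2)c1`: 35900 nM

In a functional assay on A549 cells (Homo sapiens) for antiproliferative activity, read by MTT assay (on this read-out higher numbers stand for weaker inhibition and lower numbers for stronger inhibition), compound 2 gives 35900 nM, the higher of the two numbers and thus the weaker inhibition. The gap to compound 1 lies beyond the usual scatter, but these two compounds differ in more than one place, so no single change can be credited with it.

Compound 3 `COc1ccc(-c2ccnc(Nc3cccc(OC)c3)n2)cc1` differs from compound 2 in one place: methoxy in place of fluoro on an aromatic carbon. Methoxy stands in place of fluoro on an aromatic carbon, para to a large group. Among the measured compounds shown here, no measured pair shows this swap alone, so any forecast is rough. Compound 1 also carries this methoxy and gives 2730 nM, so a moderate step to a lower number in this assay, somewhat beyond the scatter, is expected. The expected change is a 3.0-fold lower number from compound 2 to compound 3 (0.48 log units; beyond the scatter). Compound 3 is estimated at 12000 nM, with an expected range of 3000 nM to 40000 nM.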

Compound 3, half-maximal inhibitory concentration: 6530 nM
Compound 3: the middle estimate sits 1.8-fold (0.26 log units) above what was measured; the range from low to high includes it.
By their numbers in this assay, from the lowest: compound 1; then compound 3; then compound 2.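

In this assay, methoxy in place of fluoro on an aromatic carbon, para to a large group, gives a 5.5-fold lower number from compound 2 to compound 3 (0.74 log units; beyond the scatter). Among the compounds shown here, this is the first view of that swap on its own, since compound 1 and compound 2 differ in more than one place and their gap could not be credited to any single change. At this position, then, the choice between these two small groups alone moves the number beyond the usual scatter, towards stronger inhibition with methoxy. Nothing available here accounts for this step.

On these data alone, whether an amine or a longer chain such as ethoxy on that same carbon would lower the number further remains open. Also open, as far as these compounds go, is whether this swap would give a step of similar size if the shared core carried a different group elsewhere.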